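Adding a chloro group to an inactive compound

This account rests on a few compounds, and the source may have more. Where it says the series, first, only, none or still open, it means among the compounds named here.

Compound 1 `CC(=O)SCCC(CCCCC(=O)Nc1ccc(Cl)cc1)SC(C)=O` gives 9.96%
Compound 2 `O=C(CCCCC(CCSC(=O)c1ccccc1)SC(=O)c1ccccc1)Nc1ccccc1` gives "not active" (no number reported)

In a functional assay on Bel-7402 cells (Homo sapiens) for inhibition, read by MTT assay, with a stated time of 24 h, tested at 0.1 ug/mL (on this read-out lower numbers stand for less inhibition of growth and higher numbers for more inhibition of growth at the one concentration tested), compound 2 has no single number: it was reported only as ("not active" (no number reported)) and can be placed only loosely, at the low end of the scale. Compound 3 (`O=C(CCCCC(CCSC(=O)c1ccccc1)SC(=O)c1ccccc1)Nc1cccc(Cl)c1`) differs from compound 2 in one place, with chloro in place of hydrogen on an aromatic carbon, which turns the phenyl into 3-chlorophenyl. Within the data shown here, no measured pair shows what this change does here. Compound 1 also carries a chloro group but differs elsewhere, and its small value (9.96%) offers no sign of strong inhibition. The expected step in this assay is therefore small, upward if anything, and probably within the usual scatter. For compound 3 the expected inhibition is an estimated 6% with a likely range of 0% to 18% at this single concentration.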

Compound 3, percent growth inhibition at one concentration: 1.7%
The estimate for compound 3 lay 4.3 percentage points above the measured number, and the stated range covers the measured number.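

In this assay, among these compounds, compound 2 has no number, so no step from it to compound 3 can be read. Going by these compounds, what the 3-chlorophenyl group changes relative to phenyl therefore stays open. No measurement shown here offers an explanation for the result.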